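Trifluoromethyl for dimethylamino: from compound 2 to compound 4

The source may report more compounds than this note shows. Statements on the series, on what has been measured and on what is new or still open speak of the compounds shown alone.

Compound 1 `O=c1[nH]c(-c2cccc3ccccc23)nc2ccc(N3CCCCC3)cc12` gives 2240 nM in a functional assay on HCT-15 cells (Homo sapiens) for cytotoxicity, read by MTT assay, with a stated time of 2 days; on this read-out higher numbers stand for weaker inhibition and lower numbers for stronger inhibition.
Compound 2 `CCN(CC)c1ccc2nc(-c3ccccc3N(C)C)[nH]c(=O)c2c1` gives 4200 nM in this assay.
Compound 3 `Cc1ccc2nc(-c3ccccc3N(C)C)[nH]c(=O)c2c1` reaches only a limit, > 50000 nM, in this assay (the limit of > 50000 nM in this assay, at which 1 of the 3 values shown sits).

Going by the values given here, compound 2 and compound 1 sit within the usual scatter of each other, the only two numbers in this assay so far. The change to compound 4 `CCN(CC)c1ccc2nc(-c3ccccc3C(F)(F)F)[nH]c(=O)c2c1` is trifluoromethyl in place of dimethylamino on an aromatic carbon. Among the compounds with values here, the one measured step, an at least 11-fold higher number from compound 2 to compound 3 (1.07 log units; beyond the scatter), alters the group on the core rather than the group on the pendant ring, so it does not bear directly on this change. Compound 1 carries no dimethylamino on its pendant ring at all, and its 2240 nM lies within the scatter of compound 2. The expected step is therefore a 1.1-fold lower number from compound 2 to compound 4 (0.02 log units; within the scatter), none beyond the scatter. Compound 4 is estimated at 4000 nM, between 1500 nM and 12000 nM.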

Compound 4, half-maximal inhibitory concentration: 280 nM
Compound 4: middle estimate off by 14-fold (1.15 log units), on the high side, and the stated range ends above it.
By their numbers in this assay, from the lowest: compound 4; then compounds 1 and 2 (each within the scatter of the next). At a limit, above all of these: compound 3.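

In this assay, the group on an aromatic carbon ortho to a large group carries a large effect: trifluoromethyl in place of dimethylamino gives a 15-fold lower number from compound 2 to compound 4 (1.18 log units; beyond the scatter). Going by these compounds alone, the earlier single-place step changed only the group on the core, so this is the first large step seen on the pendant ring, with diethylamino held fixed. Nothing measured here bears on the cause of this step.

Going by these compounds, whether a methoxy group, a chlorine atom or a carboxylic acid at this place would give a number like that of compound 4 stays open.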